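Benzyl for Phenyl on the Shared Core

This account rests on a few compounds, and the source may have more. Where it says the series, first, only, none or still open, it means among the compounds named here.

Compound 1, `Cc1cnc(Nc2ccc(C(=O)Nc3c(C)cccc3C)cc2)nc1-c1ccccc1OC(F)(F)F`: > 500 nM in an assay on NIH3T3 cells for inhibition of Sonic hedgehog protein (Mus musculus), read by a luciferase reporter, with a stated time of 48 h; a higher number here means a weaker inhibitor, a lower number a stronger inhibitor
Compound 2, `Cc1cnc(Nc2ccc(C(=O)Nc3c(C)cccc3C)cc2)nc1-c1ccccc1`: 1.3 nM in this assay

Compound 2 holds the only number shown in this assay. For compound 1 the value > 500 nM is a limit of this assay, namely (the limit of > 500 nM in this assay, at which 1 of the 2 values shown sits). Compound 3, `Cc1cnc(Nc2ccc(C(=O)Nc3c(C)cccc3C)cc2)nc1Cc1ccccc1`, differs from compound 2 by benzyl in place of phenyl on an aromatic carbon. Within the data shown here, the single measured step, an at least 380-fold lower number from compound 1 to compound 2 (2.58 log units; beyond the scatter), concerns a change elsewhere on the molecule, so it gives only loose guidance here. A step of modest size toward a higher number is expected, a 7.7-fold higher number from compound 2 to compound 3 (0.89 log units; beyond the scatter). Compound 3 is expected at 10 nM, within a range from 2 nM to 60 nM.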

Compound 3, half-maximal inhibitory concentration: 34.3 nM
Estimate against measurement, compound 3: 3.4-fold (0.54 log units) below, within the range that was stated.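

In this assay the change from phenyl to benzyl carries a large cost, a 26-fold higher number from compound 2 to compound 3 (1.42 log units; beyond the scatter), so this position responds to how the unsubstituted ring is attached as well as to what the ring carries. Benzyl still compares well with 2-(trifluoromethoxy)phenyl, with an at least 14-fold lower number from compound 1 to compound 3 (1.16 log units; beyond the scatter) as the step. Compound 1 stands at a limit, so that step gives only a bound: the limit of > 500 nM in this assay, at which 1 of the 3 values shown sits.

On these data alone, whether a longer chain such as 2-phenylethyl would lose still more remains open. So does whether a smaller group on the phenyl ring, such as fluorine or methyl, would keep the strength of compound 2.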